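The compounds below may be only part of what the source reports. "The series", "measured", "known", "first", "only" and "open" are said of these compounds alone.

Compounds measured in an ADME assay on THP-1 cells (Homo sapiens) for cytotoxicity; on this read-out lower numbers stand for higher toxicity in this test and higher numbers for lower toxicity in this test:
- compound 1 `O[C@@H]1Cc2cc(OC(F)(F)F)ccc2N[C@H](c2cccs2)C1`: 61500 nM
- compound 2 `Cc1ccc([C@@H]2C[C@H](O)Cc3ccccc3N2)o1`: 262000 nM
- compound 3 `Cc1ccc([C@@H]2C[C@H](O)Cc3cc(F)ccc3N2)o1`: > 1140000 nM

Compound 3 carries a furan with a methyl group and a fluoro on the fused ring. In this assay compound 3 reaches only a limit of the assay, > 1140000 nM, so its standing among the numbers is open; the limit is the limit of > 1140000 nM in this assay, at which 1 of the 3 values shown sits. Among the compounds with values here, the one measured step that bears on the position in question, an at least 4.3-fold higher number from compound 2 to compound 3 (0.63 log units; beyond the scatter), moves toward lower toxicity. Compound 1 carries a trifluoromethoxy at the same place of its fused ring together with a thiophene and gives 61500 nM; it differs from compound 3 in two places, so its value is noted only as a comparison.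

Compound 4 `Cc1ccc([C@@H]2C[C@H](O)Cc3cc(OC(F)(F)F)ccc3N2)o1` follows from compound 3 by trifluoromethoxy in place of fluoro on an aromatic carbon. Within the data shown here, the step to expect in this assay is not fixed by the data: compound 3 stands at a limit, and the only guide for the trifluoromethoxy group is compound 1, which differs elsewhere as well. The expectation for compound 4 is therefore a broad one, an at least 4.5-fold lower number from compound 3 to compound 4 (0.65 log units; beyond the scatter), and compound 4 is estimated at 250000 nM, between 50000 nM and 1200000 nM.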

Compound 4, half-maximal cytotoxic concentration: 124000 nM
Compound 4: middle estimate off by 2.0-fold (0.30 log units), on the high side; the measured number falls inside the stated range.
By their numbers in this assay, from the lowest: compounds 1 and 4 (each within the scatter of the next); then compound 2. At a limit, above all of these: compound 3.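

In this assay, the group at this place now moves the number both ways against hydrogen: fluoro gives an at least 4.3-fold higher number from compound 2 to compound 3 (0.63 log units; beyond the scatter), trifluoromethoxy gives a 2.1-fold lower number from compound 2 to compound 4 (0.32 log units; beyond the scatter), and exchanging one for the other gives an at least 9.1-fold lower number from compound 3 to compound 4 (0.96 log units; beyond the scatter). From the compounds shown here alone, compound 3 stands only at a limit, so the full size of that exchange stays unknown: the limit of > 1140000 nM in this assay, at which 1 of the 4 values shown sits. With trifluoromethoxy held fixed, the swap on the saturated ring carbon gives a 2.0-fold higher number from compound 1 to compound 4 (0.30 log units; within the scatter), so 5-methylfuran-2-yl and thiophen-2-yl cannot be told apart here.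

The compounds shown give no cause for the opposite directions of fluoro and trifluoromethoxy. Going by these compounds, how an amine or a carboxylic acid at this place would read against these groups stays open, as does how thiophen-2-yl would read with fluoro.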